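Swapping the Pyridinyl Alkyne Arm for a Fluorophenyl

The source may hold more compounds than are shown below. What is called first, only, known or untested is meant among the compounds shown, and "the series" means these compounds.

The three measured compounds in a functional assay on NCI-H460 cells (Homo sapiens) for inhibition, read by sulforhodamine B assay, with a stated time of 48 h (on this read-out higher numbers stand for weaker inhibition of growth and lower numbers for stronger inhibition of growth), are:
Compound 1 `COC(=O)c1sc2cc(C#Cc3cccc(N)c3)cnc2c1N` gives 11500 nM.
Compound 2 `COC(=O)c1sc2cc(C#Cc3cccnc3)cnc2c1N` gives only a limit, > 150000 nM.
Compound 3 `COC(=O)c1sc2cc(C#Cc3ccsc3)cnc2c1N` gives 24800 nM.

Among the compounds with values here, compound 2, carrying pyridin-3-yl on the alkyne, is the one compound for which no number is known; it sits at the limit of > 150000 nM in this assay, at which 1 of the 3 values shown sits. The two other arms, 3-aminophenyl in compound 1 and thiophen-3-yl in compound 3, both give measurable numbers, and the step of a 2.2-fold higher number from compound 1 to compound 3 (0.33 log units; beyond the scatter) separates them.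

Compound 4 `COC(=O)c1sc2cc(C#Cc3ccc(F)cc3)cnc2c1N` is not yet measured. Its change from compound 2 is 4-fluorophenyl in place of pyridin-3-yl on a triple-bonded carbon. Within the data shown here, two measured steps bear on it: an at least 13-fold higher number from compound 1 to compound 2 (1.11 log units; beyond the scatter) and an at least 6.0-fold lower number from compound 2 to compound 3 (0.78 log units; beyond the scatter), both showing that the pyridin-3-yl arm gives a markedly higher number than either of the carbon-only or sulfur-containing arms tried. A 4-fluorophenyl arm is again a ring without a ring nitrogen, so the expectation for compound 4 is a step of an at least 7.5-fold lower number from compound 2 to compound 4 (0.87 log units; beyond the scatter), a lower number than the limit of compound 2, somewhere in the region of compound 1 and compound 3. The estimate for compound 4 in this assay is 20000 nM, with a range from 7000 nM to 70000 nM.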

Compound 4, concentration for 50% growth inhibition: 24000 nM
For compound 4 the middle estimate is 1.2-fold (0.08 log units) below the measured one; the measured number falls inside the stated range.
By their numbers in this assay, from the lowest: compound 1; then compounds 4 and 3 (each within the scatter of the next). At a limit, above all of these: compound 2.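

In this assay, the 4-fluorophenyl arm gives an at least 6.2-fold lower number from compound 2 to compound 4 (0.79 log units; beyond the scatter) and so shows that a measurable number at this triple-bonded carbon does not depend on the amino group of compound 1, since a ring of carbon only carrying fluorine also gives one. The step to the thiophen-3-yl arm is a 1.0-fold lower number from compound 3 to compound 4 (0.01 log units; within the scatter) and the step from the 3-aminophenyl arm is a 2.1-fold higher number from compound 1 to compound 4 (0.32 log units; beyond the scatter), which leaves compound 1 alone with the lowest number of the series, while the arms of compound 3 and compound 4 cannot be told apart here. Pyridin-3-yl remains the only arm with a ring nitrogen and the only one without a number, and the value of compound 2 is a limit of the assay: the limit of > 150000 nM in this assay, at which 1 of the 4 values shown sits.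

The compounds shown cannot tell whether the fluorine of compound 4 contributes anything, which an unsubstituted phenyl arm would settle, or whether the amine of compound 1 would count the same as a 4-aminophenyl or 3-hydroxyphenyl arm. Within the data shown here, they also leave open whether any ring nitrogen at this place goes with the high limit, or only the one in pyridin-3-yl, as a pyridin-4-yl or pyrimidin-5-yl arm would show.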